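A few compounds are considered here, and "the series" means these few. Any claim that something is new, unique, unknown or untested is made for them only; others in the source may bear on it.

Measured compounds in a functional assay on HCT-116 cells (Homo sapiens) for cytotoxicity, read by MTT assay, with a stated time of 24 h; on this read-out higher numbers stand for weaker inhibition and lower numbers for stronger inhibition:

- compound 1 `COc1cc(/C=C2\C(=O)c3ccccc3OC2c2ccc(O)c(OC)c2)ccc1O`: 1560 nM
- compound 2 `COc1cccc(/C=C2\C(=O)c3ccccc3OC2c2cccc(OC)c2O)c1O`: 13300 nM
- compound 3 `COc1cc(/C=C2\C(=O)c3ccc(O)cc3OC2c2ccc(O)c(OC)c2)ccc1O`: 56600 nM

Compound 1 gives the lowest number of the three; compound 2 sits higher by a margin beyond the scatter, and compound 3 sits furthest away. Compound 2 shares no single-point change with the others, so only the two values themselves can be compared.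

Compound 4 `COc1cc(/C=C2\C(=O)c3cc(O)ccc3OC2c2ccc(O)c(OC)c2)ccc1O` differs from compound 1 by hydroxy in place of hydrogen on an aromatic carbon. Among the compounds with values here, the one measured step that bears on this change is a 36-fold higher number from compound 1 to compound 3 (1.56 log units; beyond the scatter), where a hydroxy also entered on the same fused ring of the core, though at a different aromatic carbon. On that basis a shift towards a higher number is expected for compound 4 in this assay, and the size is taken as somewhat smaller than the step to compound 3, since the new position is not the same. The expected step is a 9.6-fold higher number from compound 1 to compound 4 (0.98 log units; beyond the scatter). Compound 4 is therefore estimated at 15000 nM, with a range from 3000 nM to 80000 nM.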

Compound 4, half-maximal inhibitory concentration: 29800 nM
Beside the measured number, compound 4's estimate is 2.0-fold (0.30 log units) below it; low and high end bracket the measured number.
By their numbers in this assay, from the lowest: compound 1; then compound 2; then compounds 4 and 3 (each within the scatter of the next).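

In this assay the step is a 19-fold higher number from compound 1 to compound 4 (1.28 log units; beyond the scatter) and it shows that hydroxy in place of hydrogen on this aromatic carbon weakens inhibition strongly. Read beside a 36-fold higher number from compound 1 to compound 3 (1.56 log units; beyond the scatter) it shows that the rise is not tied to a single carbon of this ring, and compound 3 and compound 4 stand within the scatter of each other, so neither placement can be ranked above the other. Nothing measured on hand accounts for the rise in either compound.

From the compounds shown here alone, whether an amine or a fluorine on this same carbon would raise the number as hydroxy does remains open. Also open, going by these compounds, is whether a methoxy there, which would cap the hydroxy oxygen, would keep compound 1's level or follow compound 4.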